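The source may hold more compounds than are shown below. What is called first, only, known or untested is meant among the compounds shown, and "the series" means these compounds.

Compound 3 (`NC(=O)C1CCN(c2cc3c(cc2F)c(=O)c(C(=O)NCc2ccco2)cn3C2CC2)CC1`) gives > 100000 nM in an ADME assay on J774.1 cells (Mus musculus) for cytotoxicity, read by resazurin assay, with a stated time of 48 h (a higher number here means a weaker inhibitor, a lower number a stronger inhibitor), and so stands at a limit of the assay, with no number to it. Compound 1 (`CCCCn1cc(C(=O)O)c(=O)c2cc(F)c(N3CCC(C(N)=O)CC3)cc21`) gives > 100000 nM as well, again a limit. Compound 2 (`NC(=O)C1CCN(c2cc3c(cc2F)c(=O)c(C(=O)NCc2ccccc2)cn3C2CC2)CC1`) alone returns a true number (51200 nM). Compound 4 (`NC(=O)C1CCN(c2cc3c(cc2F)c(=O)c(C(=O)O)cn3C2CC2)CC1`) follows from compound 3 with hydroxy in place of ((furan-2-yl)methyl)amino on a carbonyl carbon, so that ((furan-2-yl)methyl)carbamoyl becomes carboxy. For the measured compounds named here, the one measured step, an at least 1.9-fold higher number from compound 2 to compound 3 (0.29 log units; that floor lies within the scatter) with furan-2-yl in place of phenyl, leaves the amide-type nitrogen in place and so bears only indirectly on this change. Closer evidence comes from compound 1, which already carries a carboxy on that carbonyl carbon, though its core differs elsewhere, and which reads > 100000 nM as a limit. With the limit of > 100000 nM in this assay, at which 2 of the 3 values shown sit, in view, no step beyond the scatter is expected in this assay in either direction, and the estimated change (a step that the limit leaves unreadable from compound 3 to compound 4) stays small. For compound 4 the estimated value is 120000 nM with a range from 60000 nM to 250000 nM and it is expected that the result will most likely be reported as a limit again.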

Compound 4, half-maximal inhibitory concentration: > 100000 nM
Compound 4 gave a limit, no number; the forecaster's own chance of this, stated with the estimate: 80%; the middle value does not contradict the limit.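

In this assay, for the compounds shown here, the one new step that can be read is an at least 1.9-fold higher number from compound 2 to compound 4 (0.29 log units; that floor lies within the scatter), with hydroxy in place of benzylamino on a carbonyl carbon, so this change gives no reading beyond the scatter. The steps from compound 3 and from compound 1 to compound 4 cannot be read, as both ends of each are limits, and so the change from ((furan-2-yl)methyl)carbamoyl to carboxy has no measurable size here. What compound 4 adds is that carboxy on this carbonyl carbon reaches a limit with cyclopropyl on the aromatic nitrogen, as it does with butyl in compound 1, and the limit now holds most of the set: the limit of > 100000 nM in this assay, at which 3 of the 4 values shown sit.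

Only compound 2 returns a true number, so the compounds shown leave open whether the other three differ from one another at all. They also leave open how a plain amino group or a methoxy on this carbonyl carbon, or a longer chain in place of the benzyl on the amide nitrogen, would read in this assay.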